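A larger ring on the ester of compound 3

The source may hold more compounds than are shown below. What is called first, only, known or untested is meant among the compounds shown, and "the series" means these compounds.

Measured in an ADME assay on a cell-free system (plasma, Homo sapiens) for metabolic stability, read by LC-MS (a higher number here means that the compound lasts longer, a lower number that the compound disappears faster), are three compounds.
Compound 1 (`CCCCCCOC(=O)c1cccc(-c2cc(C(=O)Nc3ccncc3)ccc2CN)c1`) gives (0.833 h)
Compound 2 (`NCc1ccc(C(=O)Nc2ccncc2)cc1-c1cccc(C(=O)OCC2CCCCC2)c1`) gives (1.65 h)
Compound 3 (`NCc1ccc(C(=O)Nc2ccncc2F)cc1-c1cccc(C(=O)OCC2CCCO2)c1`) gives (< 0.0834 h), a limit and not a number

Compound 3 has only a limit and no number in this assay (the limit of < 0.0834 h in this assay, at which 1 of the 3 values shown sits). Compound 4 (`NCc1ccc(C(=O)Nc2ccncc2F)cc1-c1cccc(C(=O)OCC2CCCCO2)c1`) differs from compound 3 in one place (oxan-2-yl in place of oxolan-2-yl on a saturated chain carbon bound to an oxygen next to a carbonyl group), with oxan-2-yl in place of oxolan-2-yl.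

Among the compounds with values here, one measured step bears on this change. It also swaps a group on a saturated chain carbon bound to an oxygen next to a carbonyl group, and it is small (a 2.0-fold higher number from compound 1 to compound 2 (0.30 log units; within the scatter)). It is only a loose guide, since compound 1 and compound 2 have no oxygen in that ring or chain and no fluorine on the core. On this evidence, no step beyond the scatter is expected in this assay, and no direction can be favoured. The estimated step is (a step that the limit leaves unreadable from compound 3 to compound 4), and a report of only a limit would be no surprise. For compound 4 the expected half-life is about 0.08 h as an estimate, within an estimated range from 0.03 h to 0.25 h overall.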

Compound 4, half-life: 0.117 h
For compound 4 the middle estimate is 1.5-fold (0.17 log units) below the measured one; measured number inside the range.
By their numbers in this assay, from the lowest: compound 4; then compounds 1 and 2 (each within the scatter of the next). At a limit, below all of these: compound 3.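

In this assay, the step on this ester gives its first reading with an oxygen in the ring: oxan-2-yl in place of oxolan-2-yl yields an at least 1.4-fold higher number from compound 3 to compound 4 (0.14 log units; that floor lies within the scatter). Compound 3 holds a limit and not a number, so only this floor can be read: the limit of < 0.0834 h in this assay, at which 1 of the 4 values shown sits. Within the data shown here, compound 4 therefore supplies the first actual number for a ring holding oxygen at this place, whereas compound 1 and compound 2 carry no oxygen in that ring or chain and no fluorine on the core, so they differ from compound 4 in more than one place.

The compounds shown leave open whether the true step from the five-membered to the six-membered ring lies beyond the scatter. They also leave open how a ring holding an amine, such as piperidin-2-yl, would fare at this place.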